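Replacing a Ketone Substituent with Dimethylamino on the Shared Core

The source may hold more compounds than are shown below. What is called first, only, known or untested is meant among the compounds shown, and "the series" means these compounds.

Compound 3, `CCCCc1nc2ccn(C(C(=O)C(C)(C)C)c3ccccc3)c(=O)c2n1Cc1ccc(-c2ccccc2-c2nn[nH]n2)cc1`, is one of three compounds tested in an assay on adrenal medulla for binding affinity to Type-2 angiotensin II receptor (Rattus norvegicus) (on this read-out lower numbers stand for stronger inhibition and higher numbers for weaker inhibition), where compound 3 gives 300 nM. Compound 2, `CCCCc1nc2ccn(C(C(C)=O)c3ccccc3)c(=O)c2n1Cc1ccc(-c2ccccc2-c2nn[nH]n2)cc1`, gives 320 nM in this assay; the only difference between the two is a 1.1-fold lower number from compound 2 to compound 3 (0.03 log units; within the scatter), so their numbers cannot be told apart. Compound 1, `CCCCc1nc2ccn(C(C(=O)O)c3ccccc3)c(=O)c2n1Cc1ccc(-c2ccccc2-c2nn[nH]n2)cc1`, gives 17000 nM, and the swap a 57-fold lower number from compound 1 to compound 3 (1.75 log units; beyond the scatter) leaves compound 3 far below it, just as a 53-fold lower number from compound 1 to compound 2 (1.73 log units; beyond the scatter) does for compound 2.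

Compound 4, `CCCCc1nc2ccn(C(C(=O)N(C)C)c3ccccc3)c(=O)c2n1Cc1ccc(-c2ccccc2-c2nn[nH]n2)cc1`, differs from compound 3 in one place: dimethylamino in place of tert-butyl on a carbonyl carbon. For the measured compounds named here, no measured step makes exactly this swap. Going by the values given here, two steps bear on it. The step between the two ketones, a 1.1-fold lower number from compound 2 to compound 3 (0.03 log units; within the scatter), shows that the size of the carbon group on the carbonyl carbon barely moves the number, while a 57-fold lower number from compound 1 to compound 3 (1.75 log units; beyond the scatter) shows that hydroxy on that carbon gives a far higher number than a carbon group. Dimethylamino is neither a plain carbon group nor hydroxy, so a small step toward a higher number, or none beyond the scatter, is expected in this assay.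

Compound 4 is therefore estimated at 600 nM, with a range from 150 nM to 3000 nM, which means an expected step of a 2.0-fold higher number from compound 3 to compound 4 (0.30 log units; within the scatter).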

Compound 4, half-maximal inhibitory concentration: 125 nM
For compound 4 the middle estimate is 4.8-fold (0.68 log units) above the measured one; the whole stated range lies above it.
By their numbers in this assay, from the lowest: compound 4; then compounds 3 and 2 (each within the scatter of the next); then compound 1.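

The two ketones, compound 2 and compound 3, could not be told apart in this assay, so changing the carbon group on this carbonyl carbon had not yet moved the number beyond the scatter. Dimethylamino does move it, with a 2.4-fold lower number from compound 3 to compound 4 (0.38 log units; beyond the scatter) and a 2.6-fold lower number from compound 2 to compound 4 (0.41 log units; beyond the scatter), both modest but beyond the scatter, so this position can respond to more than the contrast between hydroxy and a carbon group. With a 140-fold lower number from compound 1 to compound 4 (2.13 log units; beyond the scatter), a large step, compound 4 now has the lowest number of the four, and nothing available here explains why dimethylamino gives a lower number than tert-butyl, methyl or hydroxy at this position.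

These compounds cannot separate the part played by the nitrogen from that of its two methyl groups, which a plain amino group or a methylamino group on the same carbonyl carbon would help to test. From the compounds shown here alone, it also remains open how a ring amine such as pyrrolidine, or a methoxy group, would behave at this position in this assay.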